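The compounds below may be only part of what the source reports. "The series", "measured", "known", "first", "only" and "open" are said of these compounds alone.

Measured compounds in a functional assay on MCF7 cells (Homo sapiens) for antiproliferative activity, read by sulforhodamine B assay, with a stated time of 72 h, tested at 10 uM; on this read-out higher numbers stand for a weaker effect at the one concentration tested and lower numbers for a stronger effect:
compound 1, `COc1cc(Br)cc(/C=C/C(=O)c2ccc(C)cc2)c1O`, gives 96.8%
compound 2, `COc1cc(Br)cc(/C=C/C(=O)c2ccc(Br)cc2)c1O`, gives 64.6%
compound 3, `COc1cc(Br)cc2c1OC(N)=C(C#N)C2CC(=O)c1ccc(Br)cc1`, gives 39.7%

Compound 2 and compound 1 share one core and differ in a single place: methyl in place of bromo on an aromatic carbon That change made a large step, a number 32.2 percentage points higher from compound 2 to compound 1 (beyond the scatter). Compound 3 carries a different core; how its core differs from that of compound 2 is not broken down here. In this assay compound 3 gives the lowest of the three numbers, and its gaps to compound 2 and to compound 1 both lie beyond the scatter.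

Compound 4, `COc1cc(Br)cc2c1OC(N)=C(C#N)C2CC(=O)c1ccc(C)cc1`, is not yet measured. It stands to compound 3 as compound 1 stands to compound 2: methyl in place of bromo on an aromatic carbon The place of the change reads the same in both pairs, so this is the same change carried onto the core of compound 3. Going by the values given here, only one measured instance of it exists, on the core of compound 2, and nothing shows how the core of compound 3 responds to it. For compound 4 a step of similar size is expected, a number 28.3 percentage points higher from compound 3 to compound 4 (beyond the scatter), since the same change gave a number 32.2 percentage points higher from compound 2 to compound 1 (beyond the scatter). Compound 4 is therefore estimated at about 68% in this assay, between 45% and 90%.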

Compound 4, a percentage reported as activity, at one concentration (the size of the read-out at that concentration, not a potency): 116%
For compound 4 the middle estimate is 48 percentage points below the measured one, outside the stated range (above it).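

In this assay, the change from 4-bromophenyl to 4-methylphenyl weakens the effect on the second core as well, with a number 76.3 percentage points higher from compound 3 to compound 4 (beyond the scatter). The direction of the change carries over from one core to the other, but its size does not: the same change on two cores in this assay, a number 32.2 percentage points higher (beyond the scatter) from compound 2 to compound 1 and a number 76.3 percentage points higher (beyond the scatter) from compound 3 to compound 4, 44.1 percentage points apart, beyond the scatter of two such steps. Going by these compounds alone, with only two cores, this shows that the size of the step cannot be transferred directly from the core of compound 2 to the core of compound 3, but it does not show which part of the core sets the difference or how the step would run on a further core.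

The compounds shown leave open how a chloro, a methoxy or an amine on that same aromatic carbon would compare with bromo and methyl on either core. They also leave open whether the response to this change stays core-dependent when the bromo on the core itself is replaced, for instance by a methyl.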